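Benzyl for Methyl on Selenium: Expected Cytotoxicity of Compound 4

The compounds below may be only part of what the source reports. "The series", "measured", "known", "first", "only" and "open" are said of these compounds alone.

Measured compounds:
compound 1 `CS/C(=N\C(=O)c1csc([N+](=O)[O-])c1)NC(=O)c1csc([N+](=O)[O-])c1`: > 100000 nM
compound 2 `CS/C(=N\C(=O)c1ccno1)NC(=O)c1ccno1`: > 100000 nM
compound 3 `C[Se]/C(=N\C(=O)c1ccco1)NC(=O)c1ccco1`: > 100000 nM

All three were tested in a functional assay on MCF7 cells (Homo sapiens) for cytotoxicity, read by MTT assay, with a stated time of 72 h; on this read-out lower numbers stand for higher toxicity in this test and higher numbers for lower toxicity in this test. In this assay compound 1 gives only a limit, > 100000 nM. Compound 2 likewise gives only a limit, > 100000 nM. Compound 3 also gives only a limit, > 100000 nM. Compound 3 thus sits at the limit of > 100000 nM in this assay, at which 3 of the 3 values shown sit, and no number is known for it.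

Compound 4 `O=C(/N=C(/NC(=O)c1ccco1)[Se]Cc1ccccc1)c1ccco1` differs from compound 3 by phenyl in place of hydrogen on a saturated chain carbon bound to a selenium atom. Among the compounds with values here, no step between measured compounds exists to guide this change, so the expected step from compound 3 to compound 4 is a number no higher from compound 3 to compound 4 (the limit leaves the size open), none beyond the scatter. Compound 4 is therefore estimated at 100000 nM, between 20000 nM and 300000 nM, most likely reported again only as a limit.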

Compound 4, concentration lethal to 50% of the cells: > 100000 nM
Compound 4 was reported as a limit; the forecaster's own chance of this, stated with the estimate: 75%; the middle value sits exactly at the limit.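

Within the data shown here, compound 3 and compound 4 both give only limits in this assay, so no step between them can be read. The compounds shown leave open whether any of these structures reaches a measurable value: the limit of > 100000 nM in this assay, at which 4 of the 4 values shown sit.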